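The source may hold more compounds than are shown below. What is called first, only, known or untested is meant among the compounds shown, and "the series" means these compounds.

Measured in an ADME assay on microsomes from liver (Mus musculus) for metabolic stability, read by LC-MS, with a stated time of 30 min, tested at 1 uM; a higher number here means that more of the compound is left, a lower number that less of the compound is left:
Compound 1 `O=C(NCc1ccc(S(=O)(=O)N2CCCCC2)cc1)c1cnc2nccn2c1`: 0.28%
Compound 2 `O=C(NCc1ccc(S(=O)(=O)N2CCCCC2)cc1)c1cc2cccnc2s1`: "below limit of detection" (no number reported)

In this assay, going by the values given here, compound 1 gives 0.28%, the only actual number so far, so almost none of it is left at the end of the test. For compound 2 the entry reads "below limit of detection" (no number reported), so it gives no number to compare.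

Compound 3 `O=C(NCc1ccc(S(=O)(=O)c2ccccc2)cc1)c1cnc2nccn2c1` differs from compound 1 in one group: phenyl in place of piperidin-1-yl on a sulfonyl sulfur. Put simply, it has phenyl in place of piperidin-1-yl on a sulfonyl sulfur. Among the compounds with values here, no measured pair shows what this swap does, so any expectation is loose. With compound 1 at 0.28% there is almost no room to fall, so any real change is expected to be upward. The expected change is a number 9.7 percentage points higher from compound 1 to compound 3 (within the scatter), a modest rise close to the usual scatter. For compound 3 the estimated value is 10%, with an expected range from 1% to 40%.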

Compound 3, percent of the compound remaining: 30%
The estimate for compound 3 lay 20 percentage points below the measured number, within the range that was stated.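

In this assay, going by these compounds alone, the group on the sulfonyl sulfur proves able to shift the result, with phenyl in place of piperidin-1-yl giving a number 29.7 percentage points higher from compound 1 to compound 3 (beyond the scatter), the first measured step at this position. The two groups have the same count of heavy atoms and neither has a hydrogen-bond donor or acceptor, but a six-membered aromatic ring of carbon only replaces a six-membered non-aromatic ring with one nitrogen. Nothing available explains why this swap raises the amount of compound left.

As far as these compounds go, it remains open whether phenyl would give a similar rise on the different amide partner of compound 2. It is also unclear how other groups on the sulfonyl sulfur, such as morpholin-4-yl, methyl or a pyridine ring, would compare with phenyl.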